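The compounds below may be only part of what the source reports. "The series", "measured", "known", "first", "only" and "open" are said of these compounds alone.

Measured so far in a toxicity assay on HeLa cells (Homo sapiens) for cytotoxicity, read by MTT assay, with a stated time of 24 h; on this read-out lower numbers stand for stronger inhibition and higher numbers for weaker inhibition:

compound 1 `CCN1CCN(CC(O)Cn2c([N+](=O)[O-])cnc2C)CC1` gives 4940000 nM
compound 3 `Cc1nc([N+](=O)[O-])cn1CC(O)CSC(=S)N1CCN(c2cccc(Cl)c2Cl)CC1` gives 724000 nM
compound 2 `Cc1ncc([N+](=O)[O-])n1CC(O)CN1CCN(c2cccc(Cl)c2Cl)CC1` is reported only as a limit of the assay, > 5000000 nM

Compound 3 returns a lower number than compound 1, and the gap between those two values is beyond the usual scatter. The cores of compound 2 and compound 3 differ in more than one place, and the difference between the two cores is not broken down here.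

Compound 4 `CCN1CCN(C(=S)SCC(O)Cn2cc([N+](=O)[O-])nc2C)CC1` is not yet measured in this assay. It differs from compound 3 by ethyl in place of 2,3-dichlorophenyl on an amine nitrogen in a ring. The same change is made from compound 2 to compound 1, (ethyl in place of 2,3-dichlorophenyl on an amine nitrogen in a ring), where the step was an at least 1.0-fold lower number from compound 2 to compound 1 (0.00 log units; that floor lies within the scatter). That step gives only a floor because compound 2 sits at the limit of > 5000000 nM in this assay, at which 1 of the 3 values shown sits, so it says little about how large the change is.

For compound 4 the expected step from the parent is a 1.4-fold higher number from compound 3 to compound 4 (0.14 log units; within the scatter), resting on the earlier step from compound 2 to compound 1, an at least 1.0-fold lower number from compound 2 to compound 1 (0.00 log units; that floor lies within the scatter), which shows no measurable shift from the same change. Compound 4 is estimated at 1000000 nM, expected to fall between 300000 nM and 3500000 nM.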

Compound 4, half-maximal inhibitory concentration: > 5000000 nM
Compound 4: no number, only a limit; the forecaster's own chance of this, stated with the estimate: 15%; at least 5.0-fold (0.69 log units) between middle value and limit.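

In this assay, ethyl in place of 2,3-dichlorophenyl on an amine nitrogen in a ring gives an at least 6.9-fold higher number from compound 3 to compound 4 (0.83 log units; beyond the scatter), so on the core of compound 3 this change goes with a clear rise in the number. The change does not carry over as one fixed step from one core to the other: the same change on two cores in this assay, an at least 1.0-fold lower number (0.00 log units; that floor lies within the scatter) from compound 2 to compound 1 and an at least 6.9-fold higher number (0.83 log units; beyond the scatter) from compound 3 to compound 4, at least 6.9-fold (0.84 log units) apart, beyond the scatter of two such steps Neither step has a measured size, as each one rests on a limit rather than a number, so the data show that the two steps differ but not the full size of either step or of the gap between them: the limit of > 5000000 nM in this assay, at which 2 of the 4 values shown sit.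

Among the compounds shown, only ethyl and 2,3-dichlorophenyl sit on that ring nitrogen, so it remains open whether a longer chain such as butyl, or a benzyl group, would stay near the value of compound 3 or reach the limit. Going by these compounds, the two cores differ in more than one place, and which of those differences governs the outcome of this change also remains open.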